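The source may hold more compounds than are shown below. What is called first, only, known or untested is meant among the compounds shown, and "the series" means these compounds.

In a functional assay on HT-29 cells (Homo sapiens) for inhibition, read by MTT assay, with a stated time of 2 days (on this read-out higher numbers stand for weaker inhibition and lower numbers for stronger inhibition), compound 1 `Nc1ccccc1/C=C/c1ccccc1O` gives 36 ug/mL.
In this assay compound 2 `Nc1ccc(/C=C/c2ccc(O)cc2)cc1` gives 30.6 ug/mL.
Compound 3 `COc1ccccc1/C=C/c1ccccc1N` gives only a limit, > 100 ug/mL, in this assay.

The difference between the cores of compound 1 and compound 2 is not broken down here; their two values lie within the scatter of each other. Compound 3 arises from compound 1 by one change, (methyl in place of hydrogen on an oxygen on an aromatic ring), and this change gave an at least 2.7-fold higher number from compound 1 to compound 3 (0.44 log units; beyond the scatter), a step that runs into (the limit of > 100 ug/mL in this assay, at which 1 of the 3 values shown sits). Compound 4 `COc1ccc(/C=C/c2ccc(N)cc2)cc1` is not yet measured in this assay; it differs from compound 2 by the same change, (methyl in place of hydrogen on an oxygen on an aromatic ring), at a place described in the same words. For compound 4 the expected step is a 3.6-fold higher number from compound 2 to compound 4 (0.56 log units; beyond the scatter), an expectation resting on the size of an at least 2.7-fold higher number from compound 1 to compound 3 (0.44 log units; beyond the scatter). Compound 4 is accordingly estimated at 110 ug/mL in this assay, between 50 ug/mL and 300 ug/mL, with a fair chance that only a limit is reported.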

Compound 4, half-maximal inhibitory concentration: 0.0036 ug/mL
The estimate for compound 4 lay 31000-fold (4.49 log units) above the measured number; the measured number lies below the stated range.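

In this assay, methyl in place of hydrogen on an oxygen on an aromatic ring gave an 8500-fold lower number from compound 2 to compound 4 (3.93 log units; beyond the scatter), the opposite direction to the one seen on the core of compound 1: the same change on two cores in this assay, an at least 2.7-fold higher number (0.44 log units; beyond the scatter) from compound 1 to compound 3 and an 8500-fold lower number (3.93 log units; beyond the scatter) from compound 2 to compound 4, at least 23000-fold (4.37 log units) apart, beyond the scatter of two such steps
The change thus did not carry from one core to the other in this series, in direction or in size, and the two pairs give no rule for any further core and do not show why the cores differ.
Compound 3 gives only a limit, so the true size of its step stays unknown: the limit of > 100 ug/mL in this assay, at which 1 of the 4 values shown sits.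

On these data alone, it remains open how either core would respond to an ethoxy group or a longer chain on that oxygen. As far as these compounds go, the effect of an acetamide in place of the amine on either core is also open.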